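This account rests on a few compounds, and the source may have more. Where it says the series, first, only, none or still open, it means among the compounds named here.

Series notes. Compound 1 `COc1ccccc1N1CCN(CC2=NS(=O)(=O)c3ccccc3N2)CC1` gives 5.46 in a functional assay on spleen for antagonist activity at Alpha-1B adrenergic receptor (Rattus norvegicus); a lower number here means a less potent compound, a higher number a more potent compound, by a factor of ten per unit of this negative logarithm. Compound 2 `COc1ccccc1N1CCN(CC2=NS(=O)(=O)c3ccc(Cl)cc3N2)CC1` gives 6.17 in this assay, the step being a number 0.71 log units higher from compound 1 to compound 2 (beyond the scatter). Compound 3 `COc1ccccc1N1CCN(CC2Nc3ccccc3S(=O)(=O)N2)CC1` gives 5.97 in this assay: it stands beyond the scatter above compound 1, and within the scatter of compound 2, so no order between compound 3 and compound 2 is claimed. Compound 4 `COc1ccccc1N1CCN(CC2Nc3cc(C)ccc3S(=O)(=O)N2)CC1` is not yet measured. It differs from compound 3 by methyl in place of hydrogen on an aromatic carbon. Among the compounds with values here, the only measured change on an aromatic carbon of a core in this set is a number 0.71 log units higher from compound 1 to compound 2 (beyond the scatter), which puts a different group onto the core of compound 1 rather than onto the core of compound 3; no measured step with a methyl exists, so that step bears on the present change only loosely. A step for compound 4 of a number 0.33 log units higher from compound 3 to compound 4 (beyond the scatter) is expected, upward but small and possibly within the scatter. For compound 4 a value of 6.3 is therefore estimated, with a range from 5.7 to 6.9.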

Compound 4, negative logarithm of the antagonist equilibrium constant: 6.24
Compound 4: the middle estimate sits 0.06 log units above what was measured; measured number inside the range.
By their numbers in this assay, from the lowest: compound 1; then compounds 3, 2 and 4 (each within the scatter of the next).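

In this assay, within the data shown here, methyl in place of hydrogen on an aromatic carbon gives a number 0.27 log units higher from compound 3 to compound 4 (within the scatter) and so provides the first measured step on the core of compound 3, and the first with a methyl. As this step lies within the scatter, no change can be claimed for methyl at this place, meta to a fused ring and para to a fused ring, and compound 3 and compound 4 are not ordered. No available evidence bears on the result.

Going by these compounds, whether an amine, a carboxylic acid or a longer chain at this place would give a step beyond the scatter remains open. Also open, on these data alone, is how methyl would behave on the core of compound 1, where chloro gives a number 0.71 log units higher from compound 1 to compound 2 (beyond the scatter), and how chloro would behave on the core of compound 3.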